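Leaving the pyrazolyl group: hydroxyethyl on the amine nitrogen

The source may hold more compounds than are shown below. What is called first, only, known or untested is meant among the compounds shown, and "the series" means these compounds.

Among the measured compounds shown here, in an ADME assay on BaF3 cells (Mus musculus) for inhibition, read by CellTiter-Glo, with a stated time of 72 h (a higher number here means a weaker inhibitor of growth, a lower number a stronger inhibitor of growth), compound 2 `Cc1ccc(NC(=O)c2cccc(C(F)(F)F)c2)cc1N1Cc2cnc(Nc3cnn(C)c3)nc2N(C)C1=O` gives 352 nM, the lower of the two numbers so far, and compound 1 `Cc1ccc(NC(=O)c2cccc(C(F)(F)F)c2)cc1N1Cc2cnc(NC3CC3)nc2N(C)C1=O` gives 5060 nM. The change to compound 3 `Cc1ccc(NC(=O)c2cccc(C(F)(F)F)c2)cc1N1Cc2cnc(NCCO)nc2N(C)C1=O` is 2-hydroxyethyl in place of 1-methyl-1H-pyrazol-4-yl on a nitrogen on an aromatic ring. For the measured compounds named here, the one step bearing on this is a 14-fold lower number from compound 1 to compound 2 (1.16 log units; beyond the scatter), a large one, where 1-methyl-1H-pyrazol-4-yl replaced cyclopropyl. Here the same group leaves, so a large upward step in this assay is expected, estimated as an 8.5-fold higher number from compound 2 to compound 3 (0.93 log units; beyond the scatter). The expected value for compound 3 is 3000 nM, with an estimated range of 1000 nM to 9000 nM.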

Compound 3, concentration for 50% growth inhibition: 3290 nM
Estimate against measurement, compound 3: 1.1-fold (0.04 log units) below, within the range that was stated.
By their numbers in this assay, from the lowest: compound 2; then compounds 3 and 1 (each within the scatter of the next).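

In this assay, replacing 1-methyl-1H-pyrazol-4-yl with 2-hydroxyethyl gives a step (a 9.3-fold higher number from compound 2 to compound 3 (0.97 log units; beyond the scatter)) of similar size to the one separating the pyrazolyl and cyclopropyl compounds. Cyclopropyl and 2-hydroxyethyl on this nitrogen cannot be told apart (a 1.5-fold lower number from compound 1 to compound 3 (0.19 log units; within the scatter)), so among these three groups only 1-methyl-1H-pyrazol-4-yl stands apart, with the lower number. No measurement here bears on the reason for this difference.

Going by these compounds, whether the step depends on the pyrazole ring itself or on its methyl remains open. A phenyl group, an unsubstituted pyrazol-4-yl or a longer chain ending in an amine on the same nitrogen would test this further.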